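A pyrrolidin-1-yl group on compound 3

The source may report more compounds than this note shows. Statements on the series, on what has been measured and on what is new or still open speak of the compounds shown alone.

Values in a functional assay on SK-BR-3 cells (Homo sapiens) for antiproliferative activity, read by MTT assay, with a stated time of 72 h (on this read-out higher numbers stand for weaker inhibition and lower numbers for stronger inhibition), follow

Compound 1 `CCN1CCN(c2cc(C)c3cc(NC(=O)c4ccc(F)cc4)ccc3n2)CC1` gives 19800 nM
Compound 2 `CCN1CCN(c2cc(C)c3cc(NC(=O)c4cccnc4)ccc3n2)CC1` gives 10600 nM
Compound 3 `CCNc1cc(C)c2cc(NC(=O)c3ccc(Cl)c(Cl)c3)ccc2n1` gives 28200 nM

Compound 3 lies within the scatter of compound 1, and beyond the scatter from compound 2, whose number is lower. Compound 4 `Cc1cc(NCCN2CCCC2)nc2ccc(NC(=O)c3ccc(Cl)c(Cl)c3)cc12` differs from compound 3 by pyrrolidin-1-yl in place of hydrogen on a saturated chain carbon, two bonds along the chain from a nitrogen on an aromatic ring so that ethylamino becomes (2-(pyrrolidin-1-yl)ethyl)amino. Going by the values given here, the only measured step (a 1.9-fold lower number from compound 1 to compound 2 (0.27 log units; within the scatter)) concerns the group on a carbonyl carbon, so no measured step bears directly on this chain. Resting only on the narrow spread from compound 2 (10600 nM) to compound 3 (28200 nM), a small step toward a lower number is expected in this assay and it may not clear the scatter. The estimated change is (a 1.9-fold lower number from compound 3 to compound 4 (0.27 log units; within the scatter)). Compound 4 is expected at 15000 nM (from 5000 nM to 40000 nM).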

Compound 4, half-maximal inhibitory concentration: 9530 nM
Beside the measured number, compound 4's estimate is 1.6-fold (0.20 log units) above it; the measured number falls inside the stated range.
By their numbers in this assay, from the lowest: compounds 4, 2, 1 and 3 (each within the scatter of the next, the first and the last beyond it).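

In this assay, going by these compounds alone, the change of ethylamino to (2-(pyrrolidin-1-yl)ethyl)amino gives a 3.0-fold lower number from compound 3 to compound 4 (0.47 log units; beyond the scatter) and clears the scatter, which the one earlier step, at the group on a carbonyl carbon, did not. This shows that the value responds to a change at this chain. No evidence here accounts for the shift.

As far as these compounds go, it remains open whether the pyrrolidin-1-yl ring itself matters, or whether a dimethylamino or piperidin-1-yl group, or a longer chain, would give a similar step. From the compounds shown here alone, it is also open whether the step holds with pyridin-3-yl on the carbonyl carbon.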